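Indene-to-chlorobenzocyclobutene swap in the piperazine series

The compounds below may be only part of what the source reports. "The series", "measured", "known", "first", "only" and "open" are said of these compounds alone.

For the measured compounds named here, compound 2 `C1=C(CCN2CCN(c3cccc4c3OCCO4)CC2)c2ccccc2C1` stands lowest of the three values so far in an assay for activation of Adrenergic receptor alpha-1 (Rattus norvegicus) (a higher number here means that more compound is needed for the effect, a lower number that less compound is needed), at 0.3 mg/kg. Compound 1 `c1ccc2c(c1)CC2CCN1CCN(c2cccc3c2OCCCO3)CC1` gives 6.96 mg/kg in this assay, a gap to compound 2 that lies beyond the scatter. Compound 3 `c1ccc2c(c1)CC2CCCCN1CCN(c2cccc3c2OCCO3)CC1` gives 7.15 mg/kg, also well beyond the scatter from compound 2; the values of compound 1 and compound 3 are within the scatter of each other, so nothing separates them. Compound 4 `Clc1cccc2c1CC2CCN1CCN(c2cccc3c2OCCO3)CC1` has not yet been measured. Relative to compound 2 the change is a group of 9 heavy atoms (8 carbon, 1 chlorine; one four-membered non-aromatic ring of carbon only, one six-membered aromatic ring of carbon only) in place of a group of 9 heavy atoms (9 carbon; one five-membered non-aromatic ring of carbon only, one six-membered aromatic ring of carbon only), on a saturated chain carbon, two bonds along the chain from an amine nitrogen in a ring. Going by the values given here, no step between measured compounds touches this position, so the size of the step cannot be read from a paired pair. Two of the three measured compounds carry a four-membered non-aromatic ring at this end and sit far above compound 2, which is the weak ground for expecting a move toward higher numbers rather than none. For compound 4 the estimate is 2.5 mg/kg, within 0.6 mg/kg to 10 mg/kg, because compound 2 gives 0.3 mg/kg and the expected step from an 8.3-fold higher number from compound 2 to compound 4 (0.92 log units; beyond the scatter) is toward more compound needed, with wide uncertainty.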

Compound 4, dose for half-maximal effect: 20 mg/kg
Estimate against measurement, compound 4: 8.0-fold (0.90 log units) below; the whole stated range lies below it.
By their numbers in this assay, from the lowest: compound 2; then compounds 1 and 3 (each within the scatter of the next); then compound 4.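

For the compounds shown here, at this position, on a saturated chain carbon, two bonds along the chain from an amine nitrogen in a ring, the first paired reading in this assay is large: a 67-fold higher number from compound 2 to compound 4 (1.82 log units; beyond the scatter). The size of this step shows that the readout responds strongly to the group held here, even though the two groups match in heavy-atom count at 9 each, and neither has a hydrogen-bond donor, a hydrogen-bond acceptor or a net charge. The change nevertheless bundles a four-membered ring for a five-membered one, the entry of chlorine and the loss of the double bond outside aromatic rings, so the step belongs to the whole swap, and nothing available assigns it to any one part or explains it.

As far as these compounds go, the share of the step carried by the chlorine remains open, and the unchlorinated four-membered group on the same two-carbon link and the same core would separate it from the ring change. Also open, from the compounds shown here alone, is the part played by the double bond, which a saturated five-membered ring at this position would isolate from ring size.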